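The compounds below may be only part of what the source reports. "The series", "measured", "known", "first", "only" and "open" are said of these compounds alone.

Compound 2 `COc1cc(-c2nn(-c3cccc(NC(=O)c4cccc(C(F)(F)F)c4)c3)cc2-c2ccncc2)ccc1Cl` stands at the ceiling of what a functional assay on T47D cells (Homo sapiens) for inhibition, read by sulforhodamine B assay, with a stated time of 48 h (a lower number here means a stronger inhibitor of growth, a higher number a weaker inhibitor of growth), can report: its result, > 50000 nM, is a limit of the assay and not a number, as the limit of > 50000 nM in this assay, at which 1 of the 3 values shown sits, records. Compound 1 `O=C(Nc1cccc(-n2cc(-c3ccncc3)c(-c3ccc(Cl)c(O)c3)n2)c1)Nc1cccc(C(F)(F)F)c1` likewise reaches only a limit in this assay, > 32500 nM, noted under (the limit of > 32500 nM in this assay, at which 1 of the 3 values shown sits). Compound 3 `O=C(Nc1cccc(-n2cc(-c3ccncc3)c(-c3ccc(Cl)c(O)c3)n2)c1)Nc1ccc(Cl)c(Cl)c1` alone gives a number in this assay, 17900 nM. Among the measured compounds shown here, the single measured step, an at least 1.8-fold lower number from compound 1 to compound 3 (0.25 log units; that floor lies within the scatter), concerns the aryl group on the urea and not the change considered here.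

Compound 4 `COc1cc(-c2nn(-c3cccc(NC(=O)Nc4cccc(C(F)(F)F)c4)c3)cc2-c2ccncc2)ccc1Cl` differs from compound 2 by (3-(trifluoromethyl)phenyl)amino in place of 3-(trifluoromethyl)phenyl on a carbonyl carbon. For the measured compounds named here, no measured step touches this amide-to-urea change, so no direction can be read from the data. Compound 1 carries the same urea and the same aryl group and shows only the limit > 32500 nM. Compound 4 is therefore expected to remain weak in this assay, with an estimate of 40000 nM and a range from 15000 nM to 110000 nM. The expected step of an at least 1.2-fold lower number from compound 2 to compound 4 (0.09 log units; that floor lies within the scatter) is thus essentially none beyond the scatter, with a limit the most likely outcome.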

Compound 4, concentration for total growth inhibition: > 50000 nM
Compound 4 was reported as a limit; the forecaster's own chance of this, stated with the estimate: 70%; middle value at least 1.2-fold (0.09 log units) from the limit.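

Compound 4 gives only a limit in this assay, as do compound 2 and compound 1, so neither step to compound 4 can be read. The compounds shown leave open whether (3-(trifluoromethyl)phenyl)amino in place of 3-(trifluoromethyl)phenyl, or methyl in place of hydrogen on the oxygen, changes growth inhibition at all.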